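Cap group variation on a hydroxamate series

This account rests on a few compounds, and the source may have more. Where it says the series, first, only, none or still open, it means among the compounds named here.

Measured compounds:
compound 1 `O=C(CCCCCC(NC(=O)c1cccnc1)C(=O)NCc1ccccc1)NO` 24000 nM
compound 2 `O=C(CCCCC[C@H](NC(=O)c1cc2ccccc2[nH]1)C(=O)NCc1ccccc1)NO` 1260 nM
compound 3 `O=C(/C=C/c1ccccc1)N[C@@H](CCCCCC(=O)NO)C(=O)NCc1ccccc1` 4010 nM

In a functional assay on NFF cells (Homo sapiens) for antiproliferative activity (on this read-out lower numbers stand for stronger inhibition and higher numbers for weaker inhibition), compound 3 sits second highest of the three numbers. Its nearest neighbour is compound 2, giving 1260 nM; the furthest is compound 1, giving 24000 nM.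

Compound 4 `O=C(CCCCC[C@H](NC(=O)OCc1ccccc1)C(=O)NCc1ccccc1)NO` differs from compound 3 by benzyloxy in place of 2-phenylethenyl on a carbonyl carbon. For the measured compounds named here, the only step that bears on this change is the one at the same carbonyl carbon, a 3.2-fold higher number from compound 2 to compound 3 (0.50 log units; beyond the scatter), which was modest. Going by the values given here, no measured pair shows a benzyloxy cap, so the direction is open; the expected step of a 1.3-fold lower number from compound 3 to compound 4 (0.13 log units; within the scatter) is taken as small, near the scatter. Compound 4 is therefore estimated at 3000 nM in this assay, with a range from 1000 nM to 9000 nM.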

Compound 4, half-maximal inhibitory concentration: 1520 nM
Estimate against measurement, compound 4: 2.0-fold (0.30 log units) above; low and high end bracket the measured number.
By their numbers in this assay, from the lowest: compounds 2 and 4 (each within the scatter of the next); then compound 3; then compound 1.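

In this assay the swap to benzyloxy on this carbonyl carbon gives a 2.6-fold lower number from compound 3 to compound 4 (0.42 log units; beyond the scatter) even though the two caps match in heavy-atom count and in their single six-membered aromatic ring. The change from 1H-indol-2-yl to benzyloxy gives a 1.2-fold higher number from compound 2 to compound 4 (0.08 log units; within the scatter) and so leaves the number in place, which shows that the bicyclic indole cap is not needed to reach this level. No measured data explain either step.
From the compounds shown here alone, whether the step from compound 3 follows the oxygen that enters or the double bond that leaves stays open. A 2-phenylethyl cap on the same carbonyl carbon would separate the two.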